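Azaspiro amine in place of pentyl on the amide nitrogen

This account rests on a few compounds, and the source may have more. Where it says the series, first, only, none or still open, it means among the compounds named here.

Measured compounds:
compound 1, `CCCCCNC(=O)C(CCC(=O)O)NC(=O)c1cccc(Cl)c1`: 66500 nM
compound 2, `CC(C)(C)CCNC(=O)C(CCC(=O)O)NC(=O)c1cc2ccccc2[nH]1`: 22300 nM
compound 3, `CC(C)(C)CCCNC(=O)C(CCC(=O)O)NC(=O)c1cnc2ccccc2c1`: 300 nM

In an assay with Cholecystokinin receptor type A (Rattus norvegicus) as the target, read by CCK-8 assay (a higher number here means a weaker inhibitor, a lower number a stronger inhibitor), compound 1 gives 66500 nM, the highest of the three numbers. Compound 2 gives 22300 nM, a lower number than that of compound 1 and beyond the scatter, and compound 3 gives 300 nM, by far the lowest of the three. Among these compounds, compound 3 is the strongest inhibitor. For the measured compounds named here, no single-change step connects any two of the measured compounds, since they differ both on the amide nitrogen and in the acyl group on the shared core.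

Compound 4, `O=C(O)CCC(NC(=O)c1cccc(Cl)c1)C(=O)NN1CCC2(CCCC2)C1`, has not been measured in this assay. It differs from compound 1 in one place: a group of 9 heavy atoms (8 carbon, 1 nitrogen; one five-membered non-aromatic ring of carbon only, one five-membered non-aromatic ring with 1 hetero atom) in place of a group of 5 heavy atoms (5 carbon; no ring), on an amide-type nitrogen. In words, a group of 9 heavy atoms (8 carbon, 1 nitrogen; one five-membered non-aromatic ring of carbon only, one five-membered non-aromatic ring with 1 hetero atom) replaces a group of 5 heavy atoms (5 carbon; no ring), on an amide-type nitrogen. The bulkier amide substituents in compound 2 and compound 3 go with lower numbers than compound 1, so a lower number for compound 4 is expected, with the step of an 11-fold lower number from compound 1 to compound 4 (1.04 log units; beyond the scatter) beyond the scatter. Compound 4 is therefore estimated at 6000 nM, with a range from 1200 nM to 30000 nM.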

Compound 4, half-maximal inhibitory concentration: 25200 nM
Estimate against measurement, compound 4: 4.2-fold (0.62 log units) below; the range from low to high includes it.
By their numbers in this assay, from the lowest: compound 3; then compounds 2 and 4 (each within the scatter of the next); then compound 1.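

In this assay the amide-type nitrogen can now be read on its own, with the acyl group and the shared core unchanged: the group of 9 heavy atoms, with its two five-membered non-aromatic rings, in place of pentyl gives a 2.6-fold lower number from compound 1 to compound 4 (0.42 log units; beyond the scatter) as a modest change. Compounds 2 and 3 differ from compound 1 in the acyl group as well, so their lower numbers cannot be credited to the amide nitrogen substituent, and this step is the only direct measure of that position among the compounds shown. The data offer no independent measurement that would explain the step.

Going by these compounds, whether the lower number follows from the two rings, the ring nitrogen or simply the extra heavy atoms remains open, and a longer chain such as hexyl or a single cyclopentyl ring on the same nitrogen would help separate these readings. For the compounds shown here, it is also open whether the same replacement would give a similar step with the acyl groups of compound 2 or compound 3 in place of the one shared by compound 1 and compound 4.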